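This account rests on a few compounds, and the source may have more. Where it says the series, first, only, none or still open, it means among the compounds named here.

Among the measured compounds shown here, the three compounds measured so far share a core and were all read in a functional assay on HL-60 cells (Homo sapiens) for activation, read by flow cytometry, with a stated time of 24 h, tested at 5 uM; on this read-out lower numbers stand for a weaker effect and higher numbers for a stronger effect at the one concentration tested. Compound 1 `C=C1C(=O)O[C@@H]2CC(C)=C([C@@H](C)CCCO)[C@H](O)[C@H]12` gives 7.22% in this assay. Compound 2 `CC(=O)OCCC[C@H](C)C1=C[C@@H]2[C@H](C)C(=O)O[C@@H]2C[C@@]1(C)O` gives 6.68% in this assay, and compound 3 `C=C1C(=O)O[C@H]2/C=C(\C)CC/C=C(\C)C[C@H](O)[C@@H]12` gives 9.82% in this assay. Compound 1 thus sits between the other two on the numbers, yet its distances to both compound 2 and compound 3 lie within the scatter of repeated measurements, so nothing separates the three on this read-out; all of them give small numbers.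

The next compound, compound 4 `C=C1C(=O)O[C@@H]2CC(C)=C([C@@H](C)CCCO)[C@H](OC(=O)C(C)CC)[C@H]12`, keeps the core of compound 1 and differs from it in one place: (sec-butyl)carbonyl in place of hydrogen on an oxygen on a saturated carbon, which cut one bond further out reads hydroxy to ((sec-butyl)carbonyl)oxy. For the measured compounds named here, no pair of measured compounds differs by this same change, so there is no measured step to lean on; the three values in hand merely show that the core itself, in these forms, gives low numbers.

On that basis the step is expected to be small, if anything a slight rise, and it is estimated that the step from compound 1 to compound 4 amounts to a number 3.8 percentage points higher from compound 1 to compound 4 (within the scatter) in this assay. Compound 4 is therefore expected to give about 11% in this assay, with a plausible range from 3% to 26%.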

Compound 4, a percentage reported as activity, at one concentration (the size of the read-out at that concentration, not a potency): 6.41%
The estimate for compound 4 lay 4.6 percentage points above the measured number, and the stated range covers the measured number.
By their numbers in this assay, from the lowest: compounds 4, 2, 1 and 3 (each within the scatter of the next).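

Among the compounds shown here, the change from hydroxy to ((sec-butyl)carbonyl)oxy gives the first measured step at this position, a number 0.8 percentage points lower from compound 1 to compound 4 (within the scatter), in this assay. Compound 4 carries 6 more heavy atoms on an oxygen on a saturated carbon and has lost the hydrogen there, yet this one pair shows neither a gain nor a loss that the read-out can tell apart from the scatter, so the free hydroxy is not needed to keep the number where it stands in compound 1. No measurement on these compounds bears on why the step is so small.

This single pair, read at one concentration, leaves open whether another group on this oxygen, such as benzoyl, a longer acyl chain, or an acyl group carrying an amine or a carboxylic acid, would move the number beyond the scatter. It also leaves open whether the same (sec-butyl)carbonyl on the hydroxy of compound 3 would give a step of similar size.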